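This account rests on a few compounds, and the source may have more. Where it says the series, first, only, none or still open, it means among the compounds named here.

Compound 3 `Cn1c(-c2ccc(NC(=O)CSc3nc4ccccc4s3)cc2)nc(-c2ccccc2)c1-c1ccccc1` carries a 1,3-benzothiazol-2-yl group on the sulfur of its side chain. In a functional assay on MCF7 cells (Homo sapiens) for cytotoxicity, read by MTT assay, with a stated time of 24 h, tested at 1.6 ug/mL (a higher number here means a stronger effect of the compound at the concentration tested, a lower number a weaker effect), compound 3 gives 2.1%. Among the three compounds with a number, this is the second highest, but only just: compound 2 `Cc1ccc2oc(SCC(=O)Nc3ccc(-c4nc(-c5ccccc5)c(-c5ccccc5)n4C)cc3)nc2c1` gives 1.9%, and the step of a number 0.2 percentage points higher from compound 2 to compound 3 (within the scatter) does not separate the two. Compound 1 `Cn1c(-c2ccc(NC(=O)CSc3nc4ccccc4o3)cc2)nc(-c2ccccc2)c1-c1ccccc1`, with a 1,3-benzoxazol-2-yl group on the sulfur, gives 27.4%, and the step of a number 25.3 percentage points lower from compound 1 to compound 3 (beyond the scatter) shows that the group on this sulfur can move the read-out.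

Compound 4 `Cn1nnnc1SCC(=O)Nc1ccc(-c2nc(-c3ccccc3)c(-c3ccccc3)n2C)cc1` differs from compound 3 in one place: 1-methyl-1H-tetrazol-5-yl in place of 1,3-benzothiazol-2-yl on a sulfur. The two measured steps that alter the group on this sulfur are a number 25.3 percentage points lower from compound 1 to compound 3 (beyond the scatter) and a number 0.2 percentage points higher from compound 2 to compound 3 (within the scatter), one a modest drop and the other within the scatter. Among the compounds with values here, neither involves a 1-methyl-1H-tetrazol-5-yl group, so no measured step speaks directly to this change. Compound 3 gives 2.1%, so there is little room for a step downward to compound 4, while a rise is possible but unsupported. The expected step is therefore a number 5.9 percentage points higher from compound 3 to compound 4 (within the scatter), within the scatter. For compound 4 the estimate in this assay is 8%, with a range from 0% to 30%.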

Compound 4, a percentage reported as activity, at one concentration (the size of the read-out at that concentration, not a potency): 34.3%
The estimate for compound 4 lay 26.3 percentage points below the measured number; the measured number lies above the stated range.
By their numbers in this assay, from the lowest: compounds 2 and 3 (each within the scatter of the next); then compounds 1 and 4 (each within the scatter of the next).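

In this assay, within the data shown here, the step of a number 32.2 percentage points higher from compound 3 to compound 4 (beyond the scatter) and the step of a number 32.4 percentage points higher from compound 2 to compound 4 (beyond the scatter) show that a high read-out at this sulfur does not depend on the 1,3-benzoxazol-2-yl group, the only group linked to one so far, as it also appears with 1-methyl-1H-tetrazol-5-yl, a single five-membered aromatic ring. The step of a number 6.9 percentage points higher from compound 1 to compound 4 (within the scatter) does not separate these two groups, so a six-membered aromatic ring of carbon only is not required here, and its presence does not settle the outcome: compound 1 has this ring and a high number, compounds 2 and 3 have it and low numbers, and compound 4 lacks it and has a high number. Nothing shown here explains why the read-out shifts with these groups.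

It remains open whether the methyl on the 1-methyl-1H-tetrazol-5-yl group matters, since no 1H-tetrazol-5-yl group without it appears among these compounds. Also open, going by these compounds, is what a non-aromatic group on this sulfur, such as an ethyl chain or a chain ending in an amine or a carboxylic acid, would give.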